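Thiazole carboxylic acid series: aryl ether chain homologation

The source may report more compounds than this note shows. Statements on the series, on what has been measured and on what is new or still open speak of the compounds shown alone.

Measured compounds:
compound 1 `O=C(O)c1csc([C@H]2CC[C@@H]3[C@@H](COc4cccc(F)c4)[C@H](O)C[C@@H]3O2)n1`, 5.4 nM
compound 2 `O=C(O)c1csc([C@H]2CC[C@@H]3[C@@H](COc4cccc(Cl)c4)[C@H](O)C[C@@H]3O2)n1`, 6.5 nM
compound 3 `Cc1cccc(OC[C@@H]2[C@H]3CC[C@H](c4nc(C(=O)O)cs4)O[C@H]3C[C@H]2O)c1`, 3.6 nM

In a functional assay on CHO cells for agonist activity at prostaglandin E2 receptor EP2 subtype (Homo sapiens), read by HTRF and cAMP accumulation, with a stated time of 30 min (on this read-out lower numbers stand for an effect already at smaller amounts and higher numbers for an effect only at larger amounts of compound), compound 3 gives the lowest number of the three, yet its gaps to compound 1 and compound 2 are within the scatter, so the three stand level. The measured steps all swap the substituent on the aromatic ring: a 1.2-fold higher number from compound 1 to compound 2 (0.08 log units; within the scatter), a 1.5-fold lower number from compound 1 to compound 3 (0.18 log units; within the scatter) and a 1.8-fold lower number from compound 2 to compound 3 (0.26 log units; within the scatter), each within the scatter.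

Compound 4 `O=C(O)c1csc([C@H]2CC[C@@H]3[C@@H](CCCOc4ccccc4)[C@H](O)C[C@@H]3O2)n1` changes something else: 2-phenoxyethyl in place of 3-methylphenoxy on a saturated chain carbon bound to a saturated ring carbon. The aromatic ring keeps its oxygen but moves further out along the chain on the saturated chain carbon bound to a saturated ring carbon, and the methyl is gone. Among the measured compounds shown here, no measured step touches the chain length, so the aromatic-substituent steps give little guidance beyond showing that the ring substituent itself is tolerant. From the compounds shown here alone, a change in the spacing of the aryl ether is expected to matter more, and the estimate for compound 4 is a higher number in this assay, an 8.3-fold higher number from compound 3 to compound 4 (0.92 log units; beyond the scatter), giving 30 nM with a range from 5 nM to 200 nM; the wide range reflects that this kind of change is untested here.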

Compound 4, half-maximal effective concentration: 10 nM
Compound 4: middle estimate off by 3.0-fold (0.48 log units), on the high side, and the stated range covers the measured number.
By their numbers in this assay, from the lowest: compounds 3, 1, 2 and 4 (each within the scatter of the next, the first and the last beyond it).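

In this assay, among the compounds shown here, the place on a saturated chain carbon bound to a saturated ring carbon accepts 2-phenoxyethyl with little loss: the one step beyond the scatter is the modest 2.8-fold higher number from compound 3 to compound 4 (0.44 log units; beyond the scatter), while a 1.5-fold higher number from compound 2 to compound 4 (0.19 log units; within the scatter) and a 1.9-fold higher number from compound 1 to compound 4 (0.27 log units; within the scatter) both stay within it. The longer aryl ether therefore separates compound 4 from compound 3 only and leaves it level with compound 1 and compound 2. No supporting data bear on the size of these steps.

Each step changes the chain and removes the aromatic substituent together, so the contribution of each remains unresolved. Also open, from the compounds shown here alone, are how plain phenoxy on the shorter chain, 3-methylphenoxy on the 2-phenoxyethyl chain, a still longer 3-phenoxypropyl chain, or an amine nitrogen in place of the ether oxygen would read.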